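The source may report more compounds than this note shows. Statements on the series, on what has been measured and on what is new or still open speak of the compounds shown alone.

Compound 1 (`CCCc1c(O)ccc(C(=O)/C=C/c2ccc(OC)cc2OC)c1O`) and compound 2 (`CCCc1c(O)ccc(C(=O)/C=C/c2cc(OC)c(OC)cc2OC)c1O`) share one core and differ only in their methoxy groups. In a functional assay on MCF7 cells (Homo sapiens) for inhibition, read by sulforhodamine B assay, with a stated time of 48 h (a higher number here means a weaker inhibitor of growth, a lower number a stronger inhibitor of growth), compound 1 has the entry "not determined" (no result reported), so it offers no number of its own, while compound 2 gives 9100 nM. Compound 3 (`CCCc1c(O)ccc(C(=O)/C=C/c2ccc(OC)cc2)c1O`) comes from compound 1 by a single change, hydrogen in place of methoxy on an aromatic carbon. Within the data shown here, with no result for compound 1, the size of this step in this assay cannot be read from the data, and no step between measured compounds is available as a guide. Among the measured compounds shown here, the only anchor is compound 2 at 9100 nM, and compound 3 is expected to land close to it, with no shift beyond the scatter in either direction. The estimated value for compound 3 is 10000 nM, with an expected range of 3500 nM to 30000 nM.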

Compound 3, concentration for 50% growth inhibition: 13300 nM
Beside the measured number, compound 3's estimate is 1.3-fold (0.12 log units) below it; measured number inside the range.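

No new step can be read: in this assay compound 1 offers no number to set against compound 3. The compounds shown leave open what swapping methoxy for hydrogen at this place does to growth inhibition. Nothing here bears on a cause.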